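Methyl to Methoxy on a Triazole Dithiocarbamate Series

The compounds below may be only part of what the source reports. "The series", "measured", "known", "first", "only" and "open" are said of these compounds alone.

Compound 1 `COc1ccc(-n2cc(CSC(=S)N3CCN(C(=O)OC(C)(C)C)CC3)nn2)cc1`: in a functional assay on ECa-109 cells (Homo sapiens) for inhibition, read by MTT assay, with a stated time of 72 h (on this read-out lower numbers stand for stronger inhibition and higher numbers for weaker inhibition), compound 1 gives > 128000 nM, which is a limit of the assay and not a number.
Compound 2 `Cc1ccc(-n2cc(CSC(=S)N3CCN(C(=O)OC(C)(C)C)CC3)nn2)cc1`: in this assay compound 2 gives 114000 nM.
Compound 3 `Cc1ccc(Cn2cc(CSC(=S)N3CCNCC3)nn2)cc1`: in this assay compound 3 gives > 128000 nM, which is a limit of the assay and not a number.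

All three measured compounds show weak inhibition in this assay. The change from compound 2 to compound 1 is methoxy in place of methyl on an aromatic carbon, and it made a step of an at least 1.1-fold higher number from compound 2 to compound 1 (0.05 log units; that floor lies within the scatter), a floor that lies within the scatter. The difference between the core of compound 2 and the core of compound 3 is not broken down here.

Compound 4 `COc1ccc(Cn2cc(CSC(=S)N3CCNCC3)nn2)cc1` is not yet measured. Among the compounds with values here, its relation to compound 3 is methoxy in place of methyl on an aromatic carbon, the same change as the one from compound 2 to compound 1. The step expected for compound 4 is a step that the limit leaves unreadable from compound 3 to compound 4. That expectation rests on the step of an at least 1.1-fold higher number from compound 2 to compound 1 (0.05 log units; that floor lies within the scatter) and on (the limit of > 128000 nM in this assay, at which 2 of the 3 values shown sit). The value expected for compound 4 in this assay is 160000 nM, estimated to fall between 90000 nM and 320000 nM.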

Compound 4, half-maximal inhibitory concentration: > 128000 nM
Compound 4: only a limit was reported (the forecaster's own chance of this, stated with the estimate: 80%); the middle value lies beyond the limit too.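

No step can be read from compound 3 to compound 4 in this assay, because the results for both compounds are limits and not numbers: the limit of > 128000 nM in this assay, at which 3 of the 4 values shown sit. The compounds shown leave open whether methoxy in place of methyl on an aromatic carbon changes inhibition at all, in either pair of compounds.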